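Lignan glycoside series: cytotoxicity notes, compound 2 to 4

A few compounds are considered here, and "the series" means these few. Any claim that something is new, unique, unknown or untested is made for them only; others in the source may bear on it.

The series comprises four lignan glycosides sharing the same sugar part. Compound 1 `COc1cc([C@H]2Oc3c(OC)cc(CCCO)cc3[C@@H]2CO[C@@H]2O[C@@H](C)[C@H](O)[C@@H](O)[C@H]2O)ccc1O`, compound 2 `COc1cc(C[C@H]2CO[C@@H](c3cc(OC)c(O)c(OC)c3)[C@H]2CO[C@@H]2O[C@@H](C)[C@H](O)[C@@H](O)[C@H]2O)cc(OC)c1O` and compound 3 `COc1cc([C@H]2c3c(cc(OC)c(O)c3OC)C[C@@H](CO)[C@@H]2CO[C@@H]2O[C@@H](C)[C@H](O)[C@@H](O)[C@H]2O)cc(OC)c1O` have been tested in a functional assay on HCT-15 cells (Homo sapiens) for cytotoxicity, read by sulforhodamine B assay; on this read-out lower numbers stand for stronger inhibition and higher numbers for weaker inhibition; compound 4 `COc1cc(C[C@@H]2CO[C@@H](c3cc(OC)c(O)c(OC)c3)[C@@H]2CO[C@@H]2O[C@@H](C)[C@H](O)[C@@H](O)[C@H]2O)cc(OC)c1O` has not. In this assay compound 1 reaches only the limit of the assay, > 10000 nM. In the same assay compound 2 likewise gives only a limit, > 10000 nM. Compound 3 also stops at a limit, > 10000 nM. Thus compound 2 stands nowhere above or below its neighbours on the numbers shown; all three values sit at the same boundary, as summarised by the limit of > 10000 nM in this assay, at which 3 of the 3 values shown sit, and no ordering among them can be read off.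

The step under consideration is the passage from compound 2 to compound 4, which is purely one of configuration: the two compounds have the same atoms and bonds and differ only in configuration as drawn: 2 of 8 stereo elements differ; a stereocentre at a saturated ring carbon is drawn R in compound 2 and S in compound 4; a stereocentre at a saturated ring carbon is drawn R in compound 2 and S in compound 4. Among the measured compounds shown here, no measured pair in the set differs in one place, so no measured step size is available for comparison.

Given that the whole measured set sits at the limit, no movement beyond the usual scatter is expected for this change. The step from compound 2 to compound 4 is estimated as a step that the limit leaves unreadable from compound 2 to compound 4, that is essentially none. Compound 4 is accordingly expected to give about 15000 nM in this assay, with a range of 5000 nM to 50000 nM, and most probably again only a limit.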

Compound 4, half-maximal inhibitory concentration: > 10000 nM
Compound 4 gave a limit, no number (the forecaster's own chance of this, stated with the estimate: 85%); the middle value does not contradict the limit.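

In this assay compound 4 gives > 10000 nM, which is a limit. Among the compounds shown here, as compound 2 also stops at a limit, no step from compound 2 to compound 4 can be read. The compounds shown leave open whether the configuration drawn has any effect on cytotoxicity, and how the four compounds would rank.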